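Chloro in place of methyl on compound 3

The compounds below may be only part of what the source reports. "The series", "measured", "known", "first", "only" and "open" are said of these compounds alone.

Values in an ADME assay on L02 cells (Homo sapiens) for cytotoxicity, read by MTT assay, with a stated time of 24 h (on this read-out lower numbers stand for stronger inhibition and higher numbers for weaker inhibition), are these

Compound 1 `CN1C/C(=C\c2cccnc2)C(=O)/C(=C/c2ccccc2C(F)(F)F)C1` at 14100 nM
Compound 2 `COc1cc(/C=C2\CN(C)C/C(=C\c3ccncc3)C2=O)cc(OC)c1OC` at 16400 nM
Compound 3 `Cc1ccc(S(=O)(=O)N2C/C(=C\c3cccnc3)C(=O)/C(=C/c3ccccc3F)C2)cc1` at 14900 nM

Compound 3 lies within the usual scatter of both compound 1 and compound 2, so the three values cannot be ranked. Compound 4 `O=C1/C(=C/c2cccnc2)CN(S(=O)(=O)c2ccc(Cl)cc2)C/C1=C\c1ccccc1F` differs from compound 3 by chloro in place of methyl on an aromatic carbon and carries chloro in place of methyl on an aromatic carbon, para to a large group. For the measured compounds named here, no measured pair differs in one place, so this change has no direct precedent here. With compound 3 at 14900 nM as the anchor, no step beyond the scatter is expected in this assay and no direction is favoured. The expected 1.1-fold lower number from compound 3 to compound 4 (0.03 log units; within the scatter) is therefore small. The estimate for compound 4 is 14000 nM with an expected range of 8000 nM to 25000 nM until it is measured.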

Compound 4, half-maximal inhibitory concentration: > 20000 nM
Compound 4: no number, only a limit; the forecaster's own chance of this, stated with the estimate: 5%; middle value at least 1.4-fold (0.15 log units) from the limit.
By their numbers in this assay, from the lowest: compounds 1, 3 and 2 (each within the scatter of the next). At a limit, above all of these: compound 4.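

In this assay compound 4 gives > 20000 nM, a limit of the assay and not a number. Only compound 4 sits at this limit: the limit of > 20000 nM in this assay, at which 1 of the 4 values shown sits. This is the first change in one place among the compounds shown, and 4-chlorophenyl in place of 4-methylphenyl on the sulfonyl group gives an at least 1.3-fold higher number from compound 3 to compound 4 (0.12 log units; that floor lies within the scatter), so the step has a floor but no measured size.

From the compounds shown here alone, how far compound 4 lies past the limit remains open. So does what an amine or a carboxylic acid at this position would give, and whether chloro in place of methyl acts the same way on other cores.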